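This account rests on a few compounds, and the source may have more. Where it says the series, first, only, none or still open, it means among the compounds named here.

Measured compounds:
compound 1 `Cc1cc(S(=O)(=O)NC(=O)c2ccc(N3CCN(Cc4ccccc4-c4ccc(Cl)cc4)CC3)cc2)ccc1N[C@H](CCN(C)C)CSc1ccccc1` — in an ADME assay on the whole organism (plasma, strain Sprague-Dawley) for pharmacokinetics, with Rattus norvegicus as the target, at a dose of 5 mg/kg by the oral route (on this read-out lower numbers stand for lower exposure and higher numbers for higher exposure at the dose given), compound 1 gives "not determined" (no result reported)
compound 2 `CN(C)CC[C@H](CSc1ccccc1)Nc1ccc(S(=O)(=O)NC(=O)c2ccc(N3CCN(Cc4ccccc4-c4ccc(Cl)cc4)CC3)cc2)cc1C(=O)C(F)(F)F` — 1080 ng.h/mL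

Within the data shown here, compound 2 holds the only number; for compound 1 in this assay no value was reported, so no step between measured compounds can be read. Compound 3 `CN(C)CC[C@H](CSc1ccccc1)Nc1ccc(S(=O)(=O)NC(=O)c2ccc(N3CCN(Cc4ccccc4-c4ccc(Cl)cc4)CC3)cc2)cc1C#N` is the unmeasured analogue of compound 2, differing by cyano in place of (trifluoromethyl)carbonyl on an aromatic carbon. The cyano enters on an aromatic carbon of a six-membered aromatic ring of carbon only, ortho to a large group and meta to a large group. Among the measured compounds shown here, with no measured step to lean on, the expected change from compound 2 to compound 3 in this assay is a 1.1-fold lower number from compound 2 to compound 3 (0.03 log units; within the scatter), none beyond the scatter. Compound 3 is estimated at 1000 ng.h/mL, with a range from 350 ng.h/mL to 3000 ng.h/mL.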

Compound 3, area under the concentration-time curve: 1740 ng.h/mL
Beside the measured number, compound 3's estimate is 1.7-fold (0.24 log units) below it; measured number inside the range.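

At this aromatic carbon, ortho to a large group and meta to a large group, cyano in place of (trifluoromethyl)carbonyl gives a 1.6-fold higher number from compound 2 to compound 3 (0.21 log units; within the scatter) in this assay, so the two groups are not told apart on this read-out. The smaller cyano, at 2 heavy atoms against 6, thus keeps compound 3 within the scatter of compound 2; steps to compound 1 cannot be read. No measurement shown bears on the reason for this result. Open, on these data alone, is whether an amine or a carboxylic acid at this carbon would separate from these two groups.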